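Moving the indane attachment point on the longer linker

A few compounds are considered here, and "the series" means these few. Any claim that something is new, unique, unknown or untested is made for them only; others in the source may bear on it.

Four compounds share a core carrying an indane group on a chain that leads to a ring amine. Compound 1 `c1ccc2c(c1)CCC2CCN1CCN(c2cccc3c2OCCO3)CC1` and compound 3 `c1ccc2c(c1)CC(CCN1CCN(c3cccc4c3OCCO4)CC1)C2` carry the shorter chain; compound 2 `c1ccc2c(c1)CCC2CCCN1CCN(c2cccc3c2OCCO3)CC1` and compound 4 `c1ccc2c(c1)CC(CCCN1CCN(c3cccc4c3OCCO4)CC1)C2` carry the longer one. How the cores of compound 1 and compound 2 differ is not broken down here. In an assay on isolated protein for binding affinity to 5-hydroxytryptamine receptor 1B (Rattus norvegicus) (on this read-out higher numbers stand for weaker inhibition and lower numbers for stronger inhibition), compound 1 gives 417 nM, compound 2 gives 204 nM, and compound 3 gives 692 nM.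

Among the measured pair, the change 2,3-dihydro-1H-inden-2-yl in place of 2,3-dihydro-1H-inden-1-yl on a saturated chain carbon, two bonds along the chain from an amine nitrogen in a ring produced a 1.7-fold higher number from compound 1 to compound 3 (0.22 log units; within the scatter). Compound 4 arises from compound 2 by the same kind of change, (2,3-dihydro-1H-inden-2-yl in place of 2,3-dihydro-1H-inden-1-yl on a saturated chain carbon, three bonds along the chain from an amine nitrogen in a ring), the only difference around the place being that the saturated chain carbon now sits three bonds along the chain from the amine nitrogen rather than two. Because the earlier step of a 1.7-fold higher number from compound 1 to compound 3 (0.22 log units; within the scatter) stayed within the scatter, a similarly modest step is expected here: a 1.7-fold higher number from compound 2 to compound 4 (0.23 log units; within the scatter). On that basis compound 4 is estimated to give 350 nM in this assay, with the expectation spanning 150 nM to 800 nM.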

Compound 4, inhibition constant: 1860 nM
Beside the measured number, compound 4's estimate is 5.3-fold (0.73 log units) below it; measured number above the stated range.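

On the longer chain, placing 2,3-dihydro-1H-inden-2-yl in place of 2,3-dihydro-1H-inden-1-yl gave a 9.1-fold higher number from compound 2 to compound 4 (0.96 log units; beyond the scatter) in this assay. The change therefore did not carry over with the same size from one core to the other, and a step read on the shorter chain was a poor guide to the step on the longer one: the same change on two cores in this assay, a 1.7-fold higher number (0.22 log units; within the scatter) from compound 1 to compound 3 and a 9.1-fold higher number (0.96 log units; beyond the scatter) from compound 2 to compound 4, 5.5-fold (0.74 log units) apart, beyond the scatter of two such steps. For the compounds shown here, this rests on only two matched pairs, so it shows that the size of the step depends on the core in these compounds, but it does not show why, and it gives no rule for any other core.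

The compounds shown leave open whether the step would keep growing on a still longer chain, or whether it would shrink again. They also leave open how the two attachment points would compare if an amide or an ether oxygen stood in the chain, or if a fluorine stood on the indane group.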